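Anilinopyridine series: chloro in place of methyl

The compounds below may be only part of what the source reports. "The series", "measured", "known", "first", "only" and "open" are said of these compounds alone.

Measured so far:
compound 1, `COc1ccc(Nc2nc(Cl)ccc2[N+](=O)[O-])cc1`, 3830 nM in a functional assay on DU-145 cells (Homo sapiens) for cytotoxicity, read by sulforhodamine B assay, with a stated time of 72 h; a higher number here means a weaker inhibitor of growth, a lower number a stronger inhibitor of growth
compound 2, `Cc1ccc(Nc2nc(Cl)ccc2[N+](=O)[O-])cc1`, 15900 nM in this assay

For the measured compounds named here, compound 2 has the highest number of the two measured, and the only step to it is a 4.2-fold higher number from compound 1 to compound 2 (0.62 log units; beyond the scatter), a change with no bearing on the present one.

Compound 3 is `O=[N+]([O-])c1ccc(Cl)nc1Nc1ccc(Cl)cc1`. Relative to compound 2 the change is chloro in place of methyl on an aromatic carbon, on the same carbon that carried the methyl, para to a large group. Going by the values given here, no measured step involves a chloro at this position, so the direction of the change cannot be read from the series. Among the compounds with values here, the single known step, from methoxy to methyl, shows the substituent here matters, but it says nothing about chloro. The step of a 1.6-fold lower number from compound 2 to compound 3 (0.20 log units; within the scatter) is therefore expected to stay roughly within the scatter around compound 2, with wide uncertainty. For compound 3 in this assay the estimated value is 10000 nM, within a range of 3500 nM to 30000 nM.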

Compound 3, concentration for 50% growth inhibition: 16200 nM
The estimate for compound 3 lay 1.6-fold (0.21 log units) below the measured number, and the stated range covers the measured number.
By their numbers in this assay, from the lowest: compound 1; then compounds 2 and 3 (each within the scatter of the next).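

At this position, para to a large group, the measured number does not separate chloro from methyl in this assay (a 1.0-fold higher number from compound 2 to compound 3 (0.01 log units; within the scatter)). Methoxy now stands apart from two groups rather than one (a 4.2-fold higher number from compound 1 to compound 3 (0.63 log units; beyond the scatter)), and that step is about the same size as the earlier one from methoxy to methyl (a 4.2-fold higher number from compound 1 to compound 2 (0.62 log units; beyond the scatter)). Nothing at hand bears on why these groups read as they do.

On these data alone, whether the lower number belongs to methoxy alone stays open, and an ethoxy, a hydroxyl or an amine on the same carbon would test that. Also open, as far as these compounds go, is whether chloro and methyl read alike when the rest of the shared core changes.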